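This account rests on a few compounds, and the source may have more. Where it says the series, first, only, none or still open, it means among the compounds named here.

Measured so far:
Compound 1, `Cn1ccc2c(Oc3ccc(NC(=O)c4nn(-c5ccc(Cl)c(C(F)(F)F)c5)ccc4=O)cc3F)ccnc21`, gives 13500 nM in a functional assay on HepG2 cells (Homo sapiens) for cytotoxicity, read by MTT assay, with a stated time of 72 h; on this read-out lower numbers stand for stronger inhibition and higher numbers for weaker inhibition.
Compound 2, `Cc1cc(=O)n(-c2cccc(F)c2)nc1C(=O)Nc1ccc(Oc2ncnc3[nH]ccc23)cc1`, gives 3180 nM in this assay.

Compound 2 stands lowest of the two numbers; compound 1 sits beyond the scatter above it. Compound 3, `Cc1cc(=O)n(-c2ccccc2OC(F)(F)F)nc1C(=O)Nc1ccc(Oc2ncnc3[nH]ccc23)cc1`, has not yet been measured. It differs from compound 2 by 2-(trifluoromethoxy)phenyl in place of 3-fluorophenyl on an aromatic nitrogen. Among the measured compounds shown here, no measured pair tells how such a change behaves in this assay, so no step beyond the scatter is expected in either direction. The step from compound 2 to compound 3 is estimated as a 1.3-fold higher number from compound 2 to compound 3 (0.10 log units; within the scatter). Compound 3 is expected to give about 4000 nM, within a range of 1300 nM to 12000 nM.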

Compound 3, half-maximal inhibitory concentration: 22800 nM
For compound 3 the middle estimate is 5.7-fold (0.76 log units) below the measured one, and the stated range ends below it.
By their numbers in this assay, from the lowest: compound 2; then compounds 1 and 3 (each within the scatter of the next).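

Among the compounds shown here, replacing 3-fluorophenyl with 2-(trifluoromethoxy)phenyl on the aromatic nitrogen gives the first reading of a change at this position, and in this assay it brings a 7.2-fold higher number from compound 2 to compound 3 (0.86 log units; beyond the scatter), toward weaker inhibition. This position is therefore not indifferent to the group it carries on this read-out. No measurement at hand accounts for the step.

The compounds shown leave open whether the step follows the trifluoromethoxy group itself or its place on the phenyl ring. They also leave open how a phenyl ring carrying an amine or a carboxylic acid would read here.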